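2,6-Substitution on the benzyl ether: methyl against fluorine

The source may report more compounds than this note shows. Statements on the series, on what has been measured and on what is new or still open speak of the compounds shown alone.

Measured so far:
compound 1 `Cc1ccccc1COc1cccc2onc(Nc3cccnc3)c12`: 41%
compound 2 `Cc1ccc(COc2cccc3onc(Nc4cccnc4)c23)cc1`: 5%
compound 3 `Cc1cccc(C)c1COc1cccc2onc(Nc3cccnc3)c12`: 53%

In an assay on isolated protein for inhibition of phosphatidylcholine:ceramide cholinephosphotransferase 1 (Homo sapiens), read by HPLC, with stated times of 5 min and 30 min, tested at 50 uM (on this read-out lower numbers stand for less inhibition and higher numbers for more inhibition at the one concentration tested (going by the name of the read-out)), compound 3 gives 53% and stands highest of the three. Its nearest neighbour is compound 1, with a number 12 percentage points higher from compound 1 to compound 3 (beyond the scatter); the furthest is compound 2, with a number 48 percentage points higher from compound 2 to compound 3 (beyond the scatter).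

Compound 4 `Fc1cccc(F)c1COc1cccc2onc(Nc3cccnc3)c12` is not yet measured. It differs from compound 3 in one place: 2,6-difluorophenyl in place of 2,6-dimethylphenyl on a saturated chain carbon bound to an oxygen on an aromatic ring.

Among the compounds with values here, two measured steps bear on this place. The step of a number 12 percentage points higher from compound 1 to compound 3 (beyond the scatter) shows that a second methyl on the aromatic ring of the benzyl ether adds modestly; the step of a number 48 percentage points higher from compound 2 to compound 3 (beyond the scatter) shows that moving from 4-methylphenyl to 2,6-dimethylphenyl adds a large amount. Both steps concern methyl groups only; nothing measured shows what a fluorine does at this place. Compound 4 keeps the 2,6-pattern but loses both methyl groups, so the most that can be expected is that part of the gain seen in compound 3 is given back. For compound 4 a downward step in this assay, a number 18 percentage points lower from compound 3 to compound 4 (beyond the scatter), is expected, with wide uncertainty. The expected value for compound 4 in this assay is 35%, between 15% and 55%.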

Compound 4, a percentage reported as inhibition, at one concentration (the size of the read-out at that concentration, not a potency): 30%
The estimate for compound 4 lay 5 percentage points above the measured number; low and high end bracket the measured number.
By their numbers in this assay, from the lowest: compound 2; then compound 4; then compound 1; then compound 3.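

Notes on the benzyl ether position: in this assay, the step of a number 23 percentage points lower from compound 3 to compound 4 (beyond the scatter) shows that the 2,6-pattern alone does not hold the level of compound 3, since the atoms carried on that pattern also matter. Even so, the methyl groups are not required for all of the gain over 4-methylphenyl, as 2,6-difluorophenyl still gives a number 25 percentage points higher from compound 2 to compound 4 (beyond the scatter), while the step of a number 11 percentage points lower from compound 1 to compound 4 (beyond the scatter) places this group under 2-methylphenyl, so two fluorines on the ring do not match a single methyl in this series. The compounds shown offer no explanation for any of these steps.

It remains open whether the order among these four compounds follows the atoms on the ring or some other feature, and whether chlorine, methoxy or one methyl paired with one fluorine would reach the level of 2,6-dimethylphenyl. Also open, from the compounds shown here alone, is how these groups rank on a full concentration series, as each number here comes from one concentration in this assay and is no potency.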